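Cyano for fluoro on the benzyl arm of the hydroxamate series

The compounds below may be only part of what the source reports. "The series", "measured", "known", "first", "only" and "open" are said of these compounds alone.

Of the compounds shown here, two have numbers so far in a functional assay on NCI-H23 cells (Homo sapiens) for inhibition, read by sulforhodamine B assay; on this read-out lower numbers stand for stronger inhibition of growth and higher numbers for weaker inhibition of growth. Compound 1, `O=C(CCC1=CCN(Cc2ccc(F)cc2)C1=O)NO`, gives 4670 nM in this assay. Compound 2, `O=C(CCC1=CCN(Cc2cc(C(F)(F)F)cc(C(F)(F)F)c2)C1=O)NO`, gives 2500 nM in this assay. Compound 1 holds the highest of the two numbers, and its nearest neighbour is compound 2; the gap between them lies within the scatter, so the two values show no difference that can be read as real.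

Compound 3, `N#Cc1ccc(CN2CC=C(CCC(=O)NO)C2=O)cc1`, is not yet measured in this assay. It differs from compound 1 in one place: cyano in place of fluoro on an aromatic carbon. The change sits on an aromatic carbon of a six-membered aromatic ring of carbon only, para to a large group.

Among the measured compounds shown here, no step between measured compounds is available for this change. With only the two values at hand, neither of which separates from the other beyond the scatter, no step beyond the scatter is expected for compound 3 in either direction. The step from compound 1 to compound 3 in this assay is expected to be a 1.3-fold lower number from compound 1 to compound 3 (0.13 log units; within the scatter). For compound 3 the estimate in this assay is 3500 nM, within a range from 1200 nM to 10000 nM.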

Compound 3, concentration for 50% growth inhibition in the NCI-H23 assay: 2320 nM
For compound 3 the middle estimate is 1.5-fold (0.18 log units) above the measured one; low and high end bracket the measured number.
By their numbers in the NCI-H23 assay, from the lowest: compounds 3, 2 and 1 (each within the scatter of the next).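

Among the compounds shown here, in the NCI-H23 assay, the first step at this position, on an aromatic carbon of a six-membered aromatic ring of carbon only, para to a large group, is a 2.0-fold lower number from compound 1 to compound 3 (0.30 log units; within the scatter); cyano, with its 2 heavy atoms and 1 hydrogen-bond acceptor, can therefore stand in place of fluoro here without a step in growth inhibition that can be read as real. For the compounds shown here, the two earlier compounds offered no single-place step, so this is the first direct reading of any change on the benzyl arm. In a physicochemical assay for lipophilicity (on this read-out higher numbers stand for higher lipophilicity and lower numbers for lower lipophilicity), compound 1 gives 0.571 and compound 3 gives 0.197. The same change does give a real step in the physicochemical assay, so at this position the two read-outs part ways, with lipophilicity moving while growth inhibition stays within the scatter: the measured distribution coefficient of compound 1, 0.571, and of compound 3, 0.197, a number 0.37 log units lower (beyond the scatter)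

As far as these compounds go, whether an amine or a carboxylic acid at this place would bring a step beyond the scatter in the NCI-H23 assay remains open. From the compounds shown here alone, a single step also cannot show whether lipophilicity and growth inhibition are linked anywhere else, so any such link stays untested.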